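The compounds below may be only part of what the source reports. "The series", "measured", "known", "first", "only" and "open" are said of these compounds alone.

Compound 1 `O=c1ccn(CCCCCOc2ccc(-c3ccccc3)cc2)c(=O)[nH]1`
Compound 2 `Cc1cc(C)cc(OCCCCCn2ccc(=O)[nH]c2=O)c1`
Compound 3 `Cc1cn(CCCCCOc2ccc(Br)cc2)c(=O)[nH]c1=O`

These three compounds share the same core and differ only in the group carried on the aromatic ring at the far end of the chain. All were tested in an ADME assay on HEL cells (Homo sapiens) for cytotoxicity, read by microscopy; a higher number here means that more compound is tolerated, a lower number that less compound is tolerated. In this assay compound 1 gives 100000 nM. Compound 3 gives 100000 nM, so compound 1 stands level with compound 3 at the digits shown, within the usual scatter. For compound 2 the result is > 100000 nM, which is a limit of the assay rather than a measured number; this is the limit of > 100000 nM in this assay, at which 1 of the 3 values shown sits.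

Compound 4 `O=c1ccn(CCCCCOc2ccc([N+](=O)[O-])cc2)c(=O)[nH]1` has not yet been tested. Compared with compound 1 the change is nitro in place of phenyl on an aromatic carbon. Among the compounds with values here, no pair of measured compounds differing in one place is available, so no measured step can guide the size of this one. The three measured compounds sit at or beyond the same high concentration, and nothing here points to a direction for compound 4.

Compound 4 is therefore expected to give about 100000 nM in this assay, between 50000 nM and 200000 nM, meaning an expected step of no change at the digits printed from compound 1 to compound 4 (within the scatter), which is no change beyond the scatter.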

Compound 4, minimum cytotoxic concentration: 20000 nM
Compound 4: the middle estimate sits 5.0-fold (0.70 log units) above what was measured; measured number outside the range, below it.
By their numbers in this assay, from the lowest: compound 4; then compounds 1 and 3 (each within the scatter of the next).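

Nitro in place of phenyl on an aromatic carbon, para to a large group, gives a 5.0-fold lower number from compound 1 to compound 4 (0.70 log units; beyond the scatter) in this assay and so gives the first readable step in this set. Within the data shown here, it shows that the cells' tolerance can respond to a single change at this position, whereas the earlier values alone, all at or at the limit of one high concentration, gave no measured step to show this. The size of the step is modest, but it lies beyond the scatter, and compound 4 has the lowest number of the compounds with a measured value; the data shown give no explanation for this drop.

This one step removes a phenyl ring and brings in nitro at the same time, so it cannot tell whether the gain of nitro, the loss of phenyl or both set the lower number. On these data alone, it also remains open whether an amine or a carboxylic acid at this position on the core of compound 1 would stay level with compound 1 or fall towards compound 4, and whether a longer chain would alter the step.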